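Adding a hexyl chain to compound 1

A few compounds are considered here, and "the series" means these few. Any claim that something is new, unique, unknown or untested is made for them only; others in the source may bear on it.

Values in a functional assay on HCT-116 cells (Homo sapiens) for antiproliferative activity, read by MTT assay, with a stated time of 48 h; on this read-out lower numbers stand for stronger inhibition and higher numbers for weaker inhibition:
- compound 1 `CC(CCO)n1cnc2c(Cl)nc(F)nc21`: 19800 nM
- compound 2 `CC(CCO)n1cnc2c(Cl)ncnc21`: > 50000 nM
- compound 3 `CCCCCCCC(CCO)n1cnc2c(Cl)nc(F)nc21`: not yet measured

Going by the values given here, compound 1, at 19800 nM, holds the only actual number so far. The entry for compound 2, > 50000 nM, is a limit. Compound 3 keeps the core of compound 1 and differs by hexyl in place of hydrogen on a saturated chain carbon, two bonds along the chain from an aromatic nitrogen. Among the compounds with values here, the one measured step is an at least 2.5-fold higher number from compound 1 to compound 2 (0.40 log units; beyond the scatter), with hydrogen in place of fluoro on an aromatic carbon. That step lies away from the chain, so it bears only indirectly and gives no size for this change. Within the data shown here, no measured step touches the chain, so the direction is a tentative expectation: a modestly lower number, with a range wide enough to include no change. The expected size of the change is a 2.0-fold lower number from compound 1 to compound 3 (0.30 log units; within the scatter). Compound 3 is estimated at 10000 nM, with an expected range of 2500 nM to 40000 nM.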

Compound 3, half-maximal inhibitory concentration: 17600 nM
For compound 3 the middle estimate is 1.8-fold (0.25 log units) below the measured one, and the stated range covers the measured number.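

In this assay the step reads a 1.1-fold lower number from compound 1 to compound 3 (0.05 log units; within the scatter) with hexyl in place of hydrogen on a saturated chain carbon, two bonds along the chain from an aromatic nitrogen. Going by these compounds alone, this is the first reading at this position, and it shows that a hexyl chain can be carried there without a change beyond the scatter, which the step on the aromatic carbon could not show. The only limit in the set belongs to compound 2, so it does not enter this step: the limit of > 50000 nM in this assay, at which 1 of the 3 values shown sits.

Still open, on these data alone, is whether a shorter chain such as ethyl, a longer chain such as decyl, or an amine at the end of the hexyl chain would give a different number at this position. Also open, as far as these compounds go, is whether hexyl behaves the same way on the core of compound 2, with hydrogen in place of fluoro.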